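The compounds below may be only part of what the source reports. "The series", "measured", "known", "first", "only" and "open" are said of these compounds alone.

In an ADME assay on PC-12 cells (Rattus norvegicus) for cytotoxicity, read by WST assay, with a stated time of 24 h (a higher number here means that more compound is tolerated, a lower number that less compound is tolerated), compound 1 (`O=C(/C=C/c1cccc(O)c1O)CC(=O)/C=C/c1cccc(O)c1O`) gives 39000 nM, compound 2 (`O=C(/C=C/c1ccc(O)c(O)c1)CC(=O)/C=C/c1cc(O)ccc1O`) gives 51000 nM and compound 3 (`O=C(/C=C/c1cc(O)ccc1O)CC(=O)/C=C/c1cccc(O)c1O`) gives 53000 nM. Compound 3 therefore stands level with the other two, as both of its measured steps lie within the scatter.

Compound 4 (`O=C(/C=C/c1cccc(O)c1)CC(=O)/C=C/c1cc(O)ccc1O`) differs from compound 3 by hydrogen in place of hydroxy on an aromatic carbon. This is hydrogen in place of hydroxy on an aromatic carbon, and it reads as 2,3-dihydroxyphenyl to 3-hydroxyphenyl.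

Going by the values given here, two measured steps bear on it only indirectly: a 1.4-fold higher number from compound 1 to compound 3 (0.13 log units; within the scatter) and a 1.0-fold higher number from compound 2 to compound 3 (0.02 log units; within the scatter). Among the compounds with values here, each exchanges one dihydroxyphenyl group for another, and no measured compound carries a 3-hydroxyphenyl group, so the loss of a hydroxy has no direct precedent here. With only those two small steps as a guide, no change beyond the scatter is expected in this assay, and no direction can be favoured.

The estimated move is a 1.1-fold lower number from compound 3 to compound 4 (0.03 log units; within the scatter). For compound 4 the expected value is 50000 nM, with an estimated range of 25000 nM to 100000 nM.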

Compound 4, half-maximal cytotoxic concentration: 15000 nM
For compound 4 the middle estimate is 3.3-fold (0.52 log units) above the measured one; the measured number lies below the stated range.
By their numbers in this assay, from the lowest: compound 4; then compounds 1, 2 and 3 (each within the scatter of the next).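

In this assay, going by these compounds alone, taking the hydroxy off this ring, going from 2,3-dihydroxyphenyl to 3-hydroxyphenyl, gives a 3.5-fold lower number from compound 3 to compound 4 (0.55 log units; beyond the scatter), so less compound is tolerated, whereas exchanges among the dihydroxyphenyl groups in the earlier compounds stayed within the scatter. Reaching the same 3-hydroxyphenyl group from 3,4-dihydroxyphenyl gives a step of similar size, a 3.4-fold lower number from compound 2 to compound 4 (0.53 log units; beyond the scatter), so in these compounds the loss of a hydroxy from this ring counts for more than the arrangement of the two hydroxy groups. Nothing available accounts for this shift.

Still open, going by these compounds, is whether a methoxy group or an amine in place of the hydroxy would give the same lower number as hydrogen. Also open, on these data alone, is whether losing a hydroxy from the 2,5-dihydroxyphenyl ring on the other side of the chain would give a step of similar size.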